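The source may hold more compounds than are shown below. What is called first, only, known or untested is meant among the compounds shown, and "the series" means these compounds.

Compound 1 `Fc1ccccc1CSc1nnc(-c2ccc3c(c2)OCCO3)o1`: 24000 nM
Compound 2 `Cc1ccccc1CSc1nnc(-c2ccc3c(c2)OCCO3)o1`: 22000 nM
Compound 3 `Cc1ccc(CSc2nnc(-c3ccc4c(c3)OCCO4)o2)cc1`: 41900 nM

In a functional assay on HepG2 cells (Homo sapiens) for antiproliferative activity, read by MTT assay, with a stated time of 48 h (a higher number here means a weaker inhibitor, a lower number a stronger inhibitor), compound 2 gives 22000 nM, the smallest of the three numbers, yet the step of a 1.1-fold lower number from compound 1 to compound 2 (0.04 log units; within the scatter) and the step of a 1.9-fold higher number from compound 2 to compound 3 (0.28 log units; within the scatter) both sit within the scatter, so the three measured compounds cannot be told apart. Compound 4 `Brc1ccc(CSc2nnc(-c3ccc4c(c3)OCCO4)o2)cc1` differs from compound 2 by 4-bromophenyl in place of 2-methylphenyl on a saturated chain carbon bound to a sulfur. For the measured compounds named here, two measured steps bear on this change: the step of a 1.9-fold higher number from compound 2 to compound 3 (0.28 log units; within the scatter), which moves a methyl on the benzyl ring, and the step of a 1.1-fold lower number from compound 1 to compound 2 (0.04 log units; within the scatter), which swaps a halogen for a methyl. Neither moved the number beyond the scatter, so no step beyond the scatter is expected here either, and compound 4 is estimated at 30000 nM, within 12000 nM to 75000 nM, an expected step of a 1.4-fold higher number from compound 2 to compound 4 (0.13 log units; within the scatter).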

Compound 4, half-maximal inhibitory concentration: 8540 nM
The estimate for compound 4 lay 3.5-fold (0.55 log units) above the measured number; the whole stated range lies above it.
By their numbers in this assay, from the lowest: compound 4; then compounds 2, 1 and 3 (each within the scatter of the next).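

In this assay, the place on a saturated chain carbon bound to a sulfur now responds to a change beyond the scatter: bromo in place of methyl gives the largest step (a 4.9-fold lower number from compound 3 to compound 4 (0.69 log units; beyond the scatter)). The replacement of 2-methylphenyl by 4-bromophenyl (a 2.6-fold lower number from compound 2 to compound 4 (0.41 log units; beyond the scatter)) and of 2-fluorophenyl by 4-bromophenyl (a 2.8-fold lower number from compound 1 to compound 4 (0.45 log units; beyond the scatter)) point the same way, leaving compound 4 lowest of the four. Nothing at hand accounts for these steps. From the compounds shown here alone, it remains open whether the gain belongs to bromo itself or to its place, as 2-bromophenyl and 4-chlorophenyl could show. Going by these compounds, how 4-aminophenyl would compare also remains open.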